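The source may hold more compounds than are shown below. What is called first, only, known or untested is meant among the compounds shown, and "the series" means these compounds.

Compound 3 `CCCS(=O)(=O)Nc1ccc(F)c(C(=O)c2n[nH]c3ncc(-c4ccc(C(F)(F)F)cc4)cc23)c1F` is the starting point. In an assay for binding affinity to dual specificity mitogen-activated protein kinase kinase 4 (Homo sapiens), read by KINOMEscan, tested at 100 nM (on this read-out lower numbers stand for a stronger effect and higher numbers for a weaker effect at the one concentration tested), compound 3 gives 29%. Its two companions share the same core and differ from it only in the group carried on the outer aromatic ring. Compound 1 `CCCS(=O)(=O)Nc1ccc(F)c(C(=O)c2n[nH]c3ncc(-c4cccc(F)c4)cc23)c1F` gives 8.2%, and compound 2 `CCCS(=O)(=O)Nc1ccc(F)c(C(=O)c2n[nH]c3ncc(-c4ccc(C)c(C)c4)cc23)c1F` gives 20%. The step of a number 20.8 percentage points higher from compound 1 to compound 3 (beyond the scatter) is beyond the scatter, so compound 3 stands weaker than compound 1, but the step of a number 9 percentage points higher from compound 2 to compound 3 (within the scatter) stays within the scatter, so compound 3 and compound 2 cannot be told apart. The remaining step, a number 11.8 percentage points higher from compound 1 to compound 2 (beyond the scatter), is also modest.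

Compound 4 `CCCS(=O)(=O)Nc1ccc(F)c(C(=O)c2n[nH]c3ncc(-c4ccc([N+](=O)[O-])cc4)cc23)c1F` has not yet been measured. Compared with compound 3 it differs in a single spot: nitro in place of trifluoromethyl on an aromatic carbon. The group that enters sits para to a large group on a six-membered aromatic ring of carbon only.

For the measured compounds named here, no measured step swaps trifluoromethyl for nitro. The three measured steps that bear on this position all exchange one group on that outer ring for another, and none of them moved the number by more than a modest amount. The expectation for compound 4 is therefore a step of a number 1 percentage points higher from compound 3 to compound 4 (within the scatter), not beyond the scatter in either direction. For compound 4 the estimated value in this assay is 30%, with an expected range from 15% to 50%.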

Compound 4, a percentage reported as activity, at one concentration (the size of the read-out at that concentration, not a potency): 4.2%
Beside the measured number, compound 4's estimate is 25.8 percentage points above it; measured number outside the range, below it.
By their numbers in this assay, from the lowest: compounds 4 and 1 (each within the scatter of the next); then compounds 2 and 3 (each within the scatter of the next).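

In this assay, replacing trifluoromethyl with nitro on the same carbon of the outer ring gives a number 24.8 percentage points lower from compound 3 to compound 4 (beyond the scatter) and so a stronger effect, which shows that two groups in the same place, both with no ring and no net charge, can give clearly different read-outs. The step of a number 15.8 percentage points lower from compound 2 to compound 4 (beyond the scatter) also lies beyond the scatter, while the step of a number 4 percentage points lower from compound 1 to compound 4 (within the scatter) stays within it, so compound 4 cannot be told apart from compound 1, and a group para to a large group therefore need not go with a weaker number, as compound 2 and compound 3 alone might have suggested. Nothing measured here explains why nitro and trifluoromethyl differ in this way.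

From the compounds shown here alone, it remains open whether this stronger effect is special to nitro or would also appear with a nitrile, an amine or a carboxylic acid on the same carbon. Also open, going by these compounds, is whether nitro would give a similar read-out on a different carbon of the outer ring.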